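This account rests on a few compounds, and the source may have more. Where it says the series, first, only, none or still open, it means among the compounds named here.

Measured in an ADME assay on a cell-free system (plasma, Rattus norvegicus, strain Sprague-Dawley) for protein binding:
- Compound 1 `O=C(Nc1cc(F)cc(Oc2cccnc2)c1)c1ccc(F)cc1`: 92.1%
- Compound 2 `COc1ccc(NC(=O)Nc2cc(F)cc(Oc3cccnc3)c2)cc1`: 95.1%

Compound 2, at 95.1%, lies within the usual scatter of compound 1, at 92.1%, so the two cannot be told apart on these numbers. Both compounds are heavily bound, and only a small share remains free.

Compound 3 `COc1ccc(NC(=O)Nc2cc(F)cc(Oc3cccnc3)c2)cn1` differs from compound 2 in one place, with 6-methoxypyridin-3-yl in place of 4-methoxyphenyl on an amide-type nitrogen. No measured pair among these compounds shows this change, so its size in this assay can only be judged, not read off. A modest shift towards more free compound is expected, possibly no larger than the scatter. The expected step is a 1.7-fold higher unbound fraction from compound 2 to compound 3 (0.24 log units; within the scatter). For compound 3 the estimated value is 91.5%, with an expected range of 85% to 95.5%.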

Compound 3, plasma protein binding in the plasma assay: 92.5%
The estimate for compound 3 lay 1.1-fold (0.05 log units) (unbound fraction) above the measured number; low and high end bracket the measured number.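

Among the compounds shown here, this pair gives the first measured reading of this change at this place, 6-methoxypyridin-3-yl in place of 4-methoxyphenyl on an amide-type nitrogen. In the plasma assay, the change gives a 1.5-fold higher unbound fraction from compound 2 to compound 3 (0.18 log units; within the scatter), so on these numbers the binding of the two compounds cannot be told apart. In a physicochemical assay for solubility, measured as kinetic solubility (on this read-out lower numbers stand for lower solubility and higher numbers for higher solubility), compound 2 gives < 1 ug/mL as a limit of the assay, not a number. In the physicochemical assay compound 3 gives 28 ug/mL as a measured number. In the physicochemical assay, by contrast, the same change comes with a large step that the earlier compounds could not show: the measured solubility of compound 2, < 1 ug/mL, and of compound 3, 28 ug/mL, an at least 28-fold higher number (1.44 log units; beyond the scatter)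

Going by these compounds, whether another group on the same amide-type nitrogen, such as a morpholine ring or a carboxylic acid, would give a similar pair of readings stays open. This single pair also leaves open whether the same swap would behave alike on a different core.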